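A few compounds are considered here, and "the series" means these few. Any claim that something is new, unique, unknown or untested is made for them only; others in the source may bear on it.

Measured compounds:
compound 1 `CN(C)c1ccc(C(=O)Nc2ccc(NC(=O)COc3ccc4c(=O)ccoc4c3)cc2)cc1`, 302 nM
compound 2 `Cc1cc(NC(=O)COc2ccc3c(=O)ccoc3c2)ccc1NC(=O)c1ccc(N(C)C)cc1`, 4210 nM

Both were tested in an assay on isolated protein for inhibition of Rho-associated protein kinase 2 (Homo sapiens), read by scintillation counting, radiometric assay and 33P incorporation, with a stated time of 40 min, in the presence of a further agent that is not named here; a higher number here means a weaker inhibitor, a lower number a stronger inhibitor. For the measured compounds named here, compound 2 gives the highest of the two numbers in this assay; its nearest neighbour is compound 1, and the single measured step, a 14-fold higher number from compound 1 to compound 2 (1.14 log units; beyond the scatter), is large and beyond the scatter. Compound 3 `CN(C)c1ccc(C(=O)Nc2ccc(NC(=O)COc3ccc4c(=O)ccoc4c3)cc2C(F)(F)F)cc1` has not yet been measured in this assay. It differs from compound 2 in one place: trifluoromethyl in place of methyl on an aromatic carbon. Going by the values given here, no measured step shows what a trifluoromethyl does at this carbon; the only related step is the one from hydrogen to methyl, a 14-fold higher number from compound 1 to compound 2 (1.14 log units; beyond the scatter), which weakened inhibition markedly. That step bears on compound 3 only indirectly: compound 3 keeps a substituent at the same carbon and simply exchanges methyl for trifluoromethyl. On this basis compound 3 is expected to remain on the weaker side, with a number close to that of compound 2 or somewhat higher, so the expected step is a 1.4-fold higher number from compound 2 to compound 3 (0.15 log units; within the scatter). The estimate for compound 3 in this assay is 6000 nM, in a range from 1500 nM to 25000 nM.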

Compound 3, half-maximal inhibitory concentration: 7100 nM
Estimate against measurement, compound 3: 1.2-fold (0.07 log units) below; the range from low to high includes it.
By their numbers in this assay, from the lowest: compound 1; then compounds 2 and 3 (each within the scatter of the next).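

In this assay, exchanging methyl for trifluoromethyl at this aromatic carbon gives a 1.7-fold higher number from compound 2 to compound 3 (0.23 log units; within the scatter), so the assay does not tell these two substituents apart, even though the entering group has more heavy atoms than the one it replaces. Measured against hydrogen at the same carbon, trifluoromethyl gives a 24-fold higher number from compound 1 to compound 3 (1.37 log units; beyond the scatter), a large step beyond the scatter, as was a 14-fold higher number from compound 1 to compound 2 (1.14 log units; beyond the scatter), so the large loss is no longer tied to methyl alone but appears with both substituents tested here. No measurement shown accounts for this shared loss.

The compounds shown leave open whether any group at this carbon can keep the number near that of compound 1 at 302 nM, for example a single fluorine atom, a methoxy group, an amine or a carboxylic acid. They also leave open whether the same substituents would cost as much on another carbon of this ring, or with a different group in place of the dimethylamino group.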